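A few compounds are considered here, and "the series" means these few. Any claim that something is new, unique, unknown or untested is made for them only; others in the source may bear on it.

Measured so far in an in vitro ADME assay on microsomes from liver (Mus musculus) for metabolic stability, read by LC-MS; a higher number here means that the compound lasts longer, a lower number that the compound disappears faster:
- compound 1 `CON/C(=N\C1=NC(=O)C(=O)N1C(C)C)Nc1ccc(Cl)c(Cl)c1`: > 1 h (a limit)
- compound 2 `CC(C)N/C(=N\C1=NC(=O)C(=O)N1C(C)C)Nc1ccc(Cl)c(Cl)c1`: > 1 h (a limit)
- compound 3 `CC(C)N1C(=O)C(=O)N=C1/N=C(\NCC(C)(C)C)Nc1ccc(Cl)c(Cl)c1`: > 1 h (a limit)

Compound 1 is known only through a limit, > 1 h, and not through an exact number. It has no readable rank in this small set, since all three results sit at the limit of > 1 h in this assay, at which 3 of the 3 values shown sit.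

The next compound to be tested is compound 4 `CC(C)N1C(=O)C(=O)N=C1/N=C(\NCc1ccccc1)Nc1ccc(Cl)c(Cl)c1`, which carries benzyl in place of methoxy on an amine nitrogen.

The relevant measured changes are swaps on an amine nitrogen: a step that the two limits leave unreadable from compound 1 to compound 2, a step that the two limits leave unreadable from compound 1 to compound 3 and a step that the two limits leave unreadable from compound 2 to compound 3. None of them has a readable size, so they point in no direction. Isopropyl and neopentyl both left the result at a limit, but benzyl has not been tested. In this assay, no step beyond the usual scatter is therefore expected, and another limit is the likeliest report.

The expected change is a step that the limit leaves unreadable from compound 1 to compound 4.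

For compound 4, the estimate is 1.5 h, with an expected range of 0.6 h to 4 h.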

Compound 4, half-life: > 1 h
Compound 4: a limit, no number; the forecaster's own chance of this, stated with the estimate: 70%; the middle value is on the limit's open side.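

In this assay compound 4 gives > 1 h as a limit and not a number. Going by these compounds alone, no step linking compound 4 with compound 1, compound 2 or compound 3 can be read, as all four results stand at the same limit: the limit of > 1 h in this assay, at which 4 of the 4 values shown sit. How long each of these compounds actually lasts, and whether they differ at all, stays open.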